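Phenoxy tail substituents: fluoro, methyl, tert-butyl

The compounds below may be only part of what the source reports. "The series", "measured", "known", "first", "only" and "open" are said of these compounds alone.

Measured so far:
compound 1, `Cc1nn(Cc2ccccc2Cl)c(C)c1CN(C)CC(O)CCOc1ccc(F)cc1`, 55400 nM
compound 2, `Cc1ccc(OCCC(O)CN(C)Cc2c(C)nn(Cc3ccccc3Cl)c2C)cc1`, 51500 nM

Both numbers come from an assay on cells for antagonist activity at Toll-like receptor 4 (Homo sapiens), with a stated time of 24 h; a lower number here means a stronger inhibitor, a higher number a weaker inhibitor. Compound 1 gives the highest of the two numbers, and its nearest neighbour is compound 2, with a 1.1-fold lower number from compound 1 to compound 2 (0.03 log units; within the scatter), so the two values are not separable. Among the compounds with values here, that step exchanges methyl for fluoro on an aromatic carbon of the phenoxy ring and is the only step on record.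

Compound 3, `Cc1nn(Cc2ccccc2Cl)c(C)c1CN(C)CC(O)CCOc1ccc(C(C)(C)C)cc1`, is the next member. It differs from compound 1 by tert-butyl in place of fluoro on an aromatic carbon, that is, the same aromatic carbon, para to a large group, now carries tert-butyl. Within the data shown here, the one step that bears on it, from compound 1 to compound 2, stays within the scatter, so the measured data give no direction for a change at this position; a larger group at the same place has no precedent among the measured compounds. In this assay compound 3 is therefore expected to show a 1.2-fold lower number from compound 1 to compound 3 (0.09 log units; within the scatter), with no step beyond the scatter foreseen. The estimate for compound 3 is 45000 nM, with a range from 15000 nM to 140000 nM.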

Compound 3, half-maximal inhibitory concentration: 16700 nM
Estimate against measurement, compound 3: 2.7-fold (0.43 log units) above, within the range that was stated.
By their numbers in this assay, from the lowest: compound 3; then compounds 2 and 1 (each within the scatter of the next).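

In this assay the aromatic carbon on the phenoxy tail now proves responsive to the group it carries: tert-butyl in place of fluoro gives a 3.3-fold lower number from compound 1 to compound 3 (0.52 log units; beyond the scatter) and tert-butyl in place of methyl gives a 3.1-fold lower number from compound 2 to compound 3 (0.49 log units; beyond the scatter) while the exchange of methyl for fluoro had produced no separable change. The position is therefore not indifferent to substitution, and among the three groups only tert-butyl, with 4 heavy atoms against 1 for fluoro, moves the number beyond the scatter, leaving compound 3 at 16700 nM as the lowest of the three. Nothing at hand accounts for this step.

Going by these compounds, whether the change follows the count of heavy atoms or is particular to tert-butyl stays open, and a trifluoromethyl, a methoxy, an amine or a carboxylic acid on the same aromatic carbon would help separate the two readings. Also open, on these data alone, is whether a longer chain at this place would lower the number further, and whether the tert-butyl step would hold with other changes to the shared core.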